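Cyclohexyl for 4-chlorophenyl on the ring nitrogen

The compounds below may be only part of what the source reports. "The series", "measured", "known", "first", "only" and "open" are said of these compounds alone.

Compound 1 `O=C1COc2ccc(-c3cccc(NS(=O)(=O)c4ccc(F)cc4)c3)cc2N1` gives 20100 nM here
Compound 2 `O=C1COc2ccc(-c3cccc(NS(=O)(=O)c4ccc(F)cc4)c3)cc2N1c1ccc(Cl)cc1` gives 32500 nM here

Among the compounds with values here, both numbers come from a functional assay on A-375 cells (Homo sapiens) for antiproliferative activity, read by MTT assay, with a stated time of 72 h (on this read-out higher numbers stand for weaker inhibition and lower numbers for stronger inhibition), and compound 2 lies within the scatter of compound 1, the only other number so far. Compound 3 `O=C1COc2ccc(-c3cccc(NS(=O)(=O)c4ccc(F)cc4)c3)cc2N1C1CCCCC1` makes one change to compound 2: cyclohexyl in place of 4-chlorophenyl on an amide-type nitrogen in a ring. Within the data shown here, the only measured step at this nitrogen is a 1.6-fold higher number from compound 1 to compound 2 (0.21 log units; within the scatter) and no cyclohexyl compound has been measured, so no step beyond the scatter is expected. The estimated step is a 1.3-fold lower number from compound 2 to compound 3 (0.10 log units; within the scatter) in size. Compound 3 is expected at 26000 nM with 12000 nM to 55000 nM as the estimated range.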

Compound 3, half-maximal inhibitory concentration: 23800 nM
Beside the measured number, compound 3's estimate is 1.1-fold (0.04 log units) above it; the range from low to high includes it.
By their numbers in this assay, from the lowest: compounds 1, 3 and 2 (each within the scatter of the next).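

Swapping 4-chlorophenyl for cyclohexyl on this ring nitrogen gives a 1.4-fold lower number from compound 2 to compound 3 (0.14 log units; within the scatter) in this assay and so shows no difference between an aromatic and a non-aromatic six-membered carbon ring here. Placing cyclohexyl on the nitrogen in place of its hydrogen gives a 1.2-fold higher number from compound 1 to compound 3 (0.07 log units; within the scatter) as well, so all three compounds read alike. No measurement offered here accounts for this result.

As far as these compounds go, whether an amine, a carboxylic acid or a longer chain on this nitrogen would move the number beyond the scatter stays open.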